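The source may report more compounds than this note shows. Statements on the series, on what has been measured and on what is new or still open speak of the compounds shown alone.

Measured compounds in an assay for inhibition of MAP kinase-interacting serine/threonine-protein kinase 1 (Homo sapiens), read by luminescence and ADP-Glo, with a stated time of 2 h; on this read-out higher numbers stand for weaker inhibition and lower numbers for stronger inhibition:

Compound 1, `NC(=O)c1cccc(Cn2cc(-c3ccc4cn[nH]c4c3)ccc2=O)c1`, gives 388 nM.

Compound 2, `Cn1ncc2ccc(-c3ccc(=O)n(Cc4ccccc4)c3)cc21`, gives only a limit of the assay, > 2000 nM.

Compound 3, `O=C(N1CCOCC1)n1cc(-c2ccc3cn[nH]c3c2)ccc1=O`, gives only a limit of the assay, > 2000 nM.

Compound 3 therefore stands at the weak end of what has been seen so far: it is one of two compounds that reach the limit, as summed up in the limit of > 2000 nM in this assay, at which 2 of the 3 values shown sit, while compound 1 alone shows a measured number.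

Compound 4, `Nc1cccc(Cn2cc(-c3ccc4cn[nH]c4c3)ccc2=O)c1`, has not yet been tested. It differs from compound 3 in one place: 3-aminobenzyl in place of (morpholin-4-yl)carbonyl on an aromatic nitrogen. In plain words, the carbonyl-linked morpholine ring that compound 3 carries on the ring nitrogen is replaced by a benzyl group bearing an amino group.

Within the data shown here, no directly measured step of this kind is available, so the expectation rests on what the measured compounds show. Compound 1 also carries a substituted benzyl on the same aromatic nitrogen and gives 388 nM, a measured number rather than a limit. Compound 4 is therefore expected to move toward stronger inhibition in this assay, beyond the usual scatter, with an estimated step of an at least 4.0-fold lower number from compound 3 to compound 4 (0.60 log units; beyond the scatter). For compound 4 the estimate is 500 nM, with a likely range from 200 nM to 1500 nM.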

Compound 4, half-maximal inhibitory concentration: 287 nM
Beside the measured number, compound 4's estimate is 1.7-fold (0.24 log units) above it, within the range that was stated.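

In this assay, among these compounds, compounds 3 and 4 form the first pair that differs in one place, and replacing (morpholin-4-yl)carbonyl with 3-aminobenzyl on the aromatic nitrogen gives an at least 6.9-fold lower number from compound 3 to compound 4 (0.84 log units; beyond the scatter). The second comparison stays on the benzyl ring, where amino in place of carbamoyl on an aromatic carbon gives a 1.4-fold lower number from compound 1 to compound 4 (0.13 log units; within the scatter), so this read-out does not separate these two groups, and a substituted benzyl on this nitrogen is now seen with either of them. Compound 3 gives only a limit of the assay, so the first step has a true number at one end only: the limit of > 2000 nM in this assay, at which 2 of the 4 values shown sit.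

Going by these compounds, it remains open whether a plain benzyl group on the core of compound 4, with nothing in place of the amino group, would give a similar value. Also open, on these data alone, is how a carboxylic acid or a methoxy group would read at that spot on the benzyl ring, and how a longer chain between this ring and the aromatic nitrogen would read.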